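The compounds below may be only part of what the source reports. "The series", "measured", "known", "first", "only" and "open" are said of these compounds alone.

For the measured compounds named here, compound 1 `CCC[C@H](NC(=O)N1C/C(=C\c2ccc(F)cc2)C(=O)/C(=C/c2ccc(F)cc2)C1)B1OC(C)(C)C(C)(C)O1` is one of two compounds measured in a functional assay on HCT-116 cells (Homo sapiens) for antiproliferative activity, read by MTT assay, with a stated time of 72 h; on this read-out higher numbers stand for weaker inhibition and lower numbers for stronger inhibition. There compound 1 gives 785 nM, and compound 2 `CC(C)C[C@H](NC(=O)[C@@H](NC(=O)N1C/C(=C\c2ccc(F)cc2)C(=O)/C(=C/c2ccc(F)cc2)C1)C(C)C)B1OC(C)(C)C(C)(C)O1` gives 534 nM, a number within the usual scatter of that of compound 1. No change between measured compounds has been followed one at a time. Compound 3 `CC1(C)OB([C@@H](NC(=O)N2C/C(=C\c3ccc(F)cc3)C(=O)/C(=C/c3ccc(F)cc3)C2)C2CCCCC2)OC1(C)C` has not been measured; it differs from compound 1 by cyclohexyl in place of propyl on a saturated chain carbon bound to an amide-type nitrogen and a boron atom. Going by the values given here, with no comparable step on record, the step from compound 1 to compound 3 is expected to be small, a 1.3-fold lower number from compound 1 to compound 3 (0.12 log units; within the scatter), in either direction or none beyond the scatter. Compound 3 is therefore estimated at 600 nM, between 250 nM and 1800 nM.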

Compound 3, half-maximal inhibitory concentration: 903 nM
For compound 3 the middle estimate is 1.5-fold (0.18 log units) below the measured one, and the stated range covers the measured number.
By their numbers in this assay, from the lowest: compounds 2, 1 and 3 (each within the scatter of the next).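

In this assay, cyclohexyl in place of propyl on a saturated chain carbon bound to an amide-type nitrogen and a boron atom gives a 1.2-fold higher number from compound 1 to compound 3 (0.06 log units; within the scatter) and thus no change beyond the scatter. This place therefore accepts a six-membered non-aromatic ring of carbon as well as an open propyl chain, with the number holding on this read-out. Nothing on hand gives a reason for this result. As far as these compounds go, what an amine, a carboxylic acid or a phenyl ring would do at this place remains open.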